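The compounds below may be only part of what the source reports. "The series", "measured", "known", "first", "only" and "open" are said of these compounds alone.

Working notes on the series. Two members have so far been run in an ADME assay on L02 cells (Homo sapiens) for antiproliferative activity, read by MTT assay, with a stated time of 48 h; a lower number here means a stronger inhibitor, a higher number a weaker inhibitor. Compound 1 is `Cc1ccc(C)c(-n2nncc2CN2C(=O)C3(C(C#N)=C(N)Oc4c3c3nc5ccccc5nc3c3ccccc43)c3ccccc32)c1`. In this assay compound 1 returns only the limit > 50000 nM, not a number. Compound 2 is `N#CC1=C(N)Oc2c(N)cc3nc4ccccc4nc3c2C12C(=O)N(Cc1cnnn1-c1ccc(F)cc1)c1ccccc12`. In this assay compound 2 likewise sits at the limit > 50000 nM, again a limit rather than a measured figure. Where compound 2 stands is thus known only as a limit, and the single other value in hand is a limit as well: the limit of > 50000 nM in this assay, at which 2 of the 2 values shown sit.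

Compound 3, `Cc1ccc(Cl)cc1-n1nncc1CN1C(=O)C2(C(C#N)=C(N)Oc3c(N)cc4nc5ccccc5nc4c32)c2ccccc21`, is the next member due in this assay. It differs from compound 2 in one place: 5-chloro-2-methylphenyl in place of 4-fluorophenyl on an aromatic nitrogen. Among the measured compounds shown here, no step between two measured compounds exists, so nothing quantifies what such an exchange does here.

Since compound 2 shows only the limit > 50000 nM, the step that the limit leaves unreadable from compound 2 to compound 3 is expected to be none beyond the scatter, with compound 3 most likely returning a limit too. Compound 3 is expected to give 60000 nM in this assay. For compound 3 the expected range runs from 20000 nM to 200000 nM.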

Compound 3, half-maximal inhibitory concentration: > 50000 nM
Compound 3 gave a limit, no number (the forecaster's own chance of this, stated with the estimate: 85%); the middle value is on the limit's open side.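

No step can be read between compound 2 and compound 3, since both return only a limit in this assay and the exchange of 4-fluorophenyl for 5-chloro-2-methylphenyl therefore stays unquantified: the limit of > 50000 nM in this assay, at which 3 of the 3 values shown sit. The compounds shown leave open whether any member of the series gives a numerical reading in this assay, and what such an exchange does to it.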